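The compounds below may be only part of what the source reports. "The series", "measured", "known", "first", "only" and "open" are said of these compounds alone.

Of the compounds shown here, two of the shared core have been read in a functional assay (muscle tissue) with Cavia porcellus as the target (on this read-out lower numbers stand for an effect already at smaller amounts and higher numbers for an effect only at larger amounts of compound), so far. Compound 1 `COC(=O)C1=C(C)N=C(C)/C(=C(\O)OC)C1c1c(F)c(F)c(F)c(F)c1F` gives 4.37 nM, and compound 2 `COC(=O)C1=C(C)N=C(C)/C(=C(\O)OC)C1c1cccc(O)c1` gives 1000 nM, the higher of the two numbers, the gap to compound 1 lying beyond the scatter. Compound 3 `COC(=O)C1=C(C)N=C(C)/C(=C(\O)OC)C1c1ccccc1F` has not been measured; it differs from compound 2 by 2-fluorophenyl in place of 3-hydroxyphenyl on a saturated ring carbon. Going by the values given here, no step of this kind has been measured, so the expected step of a 17-fold lower number from compound 2 to compound 3 (1.22 log units; beyond the scatter) is a downward one, partly because compound 1 gives 4.37 nM. Compound 3 is estimated at 60 nM, with a range from 6 nM to 600 nM.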

Compound 3, half-maximal effective concentration: 42.7 nM
Compound 3: middle estimate off by 1.4-fold (0.15 log units), on the high side; measured number inside the range.
By their numbers in this assay, from the lowest: compound 1; then compound 3; then compound 2.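

Replacing 3-hydroxyphenyl with 2-fluorophenyl on the saturated ring carbon gives, in this assay, a 23-fold lower number from compound 2 to compound 3 (1.37 log units; beyond the scatter). This position therefore responds strongly to an exchange that keeps the heavy-atom count of the group and the six-membered aromatic carbon ring, while the hydrogen-bond donor and acceptor counted on the leaving group disappear.

As far as these compounds go, whether the step follows from losing the hydroxyl or from gaining fluorine stays open, and a plain phenyl or a 3-aminophenyl group at this place would separate those readings. No measurement at hand accounts for the step.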